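From Methyl to Nitro on a Shared Core

The source may report more compounds than this note shows. Statements on the series, on what has been measured and on what is new or still open speak of the compounds shown alone.

In a physicochemical assay for pharmacokinetics, at pH 6 (on this read-out lower numbers stand for a shorter-lived compound and higher numbers for a longer-lived compound), compound 1 `COc1ccc(C(=O)Sc2cccnc2C(=O)O)cc1` gives 43.9 h and compound 2 `Cc1ccc(C(=O)Sc2cccnc2C(=O)O)cc1` gives 25.6 h so the two numbers stand within the scatter of each other. Compound 3 `O=C(Sc1cccnc1C(=O)O)c1ccc([N+](=O)[O-])cc1` has not yet been measured. It differs from compound 2 by nitro in place of methyl on an aromatic carbon, para to a large group (nitro in place of methyl on an aromatic carbon). Going by the values given here, only one measured step bears on this change, namely a 1.7-fold lower number from compound 1 to compound 2 (0.23 log units; within the scatter) with methyl in place of methoxy on an aromatic carbon. That step stays within the scatter and involves nitro at no point, so it offers a direction at best and fixes no firm size. Taking the direction of that single step as a weak guide, a lower number is expected for the new compound, and the uncertainty remains wide. The expected step in this assay is a 5.1-fold lower number from compound 2 to compound 3 (0.71 log units; beyond the scatter) and this estimate would carry it beyond the scatter. For compound 3 the estimate is 5 h with an expected range from 1 h to 20 h once it is measured.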

Compound 3, half-life: 1.4 h
Estimate against measurement, compound 3: 3.6-fold (0.55 log units) above, and the stated range covers the measured number.
By their numbers in this assay, from the lowest: compound 3; then compounds 2 and 1 (each within the scatter of the next).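

In this assay, the aromatic carbon para to a large group turns out to be able to carry a large change: nitro in place of methyl gives an 18-fold lower number from compound 2 to compound 3 (1.26 log units; beyond the scatter) and stands beyond the scatter, and nitro in place of methoxy gives a 31-fold lower number from compound 1 to compound 3 (1.50 log units; beyond the scatter) and stands beyond it as well. Compounds 1 and 2, with methoxy and methyl at this place, stood within the scatter of each other and so gave no sign that the group here mattered much to this read-out; with nitro the position separates clearly, and compound 3 is the shortest-lived of the three. No measurement at hand speaks to what lies behind this drop.

The compounds shown leave open whether the drop belongs to nitro alone or would also appear with another group at this place, such as an amine, a nitrile or a trifluoromethyl. They also leave open whether nitro would give a step of similar size at another place on the same ring, since all three groups sit at a single position.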